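Swapping the amide substituent of compound 3 for an oxetane

The source may report more compounds than this note shows. Statements on the series, on what has been measured and on what is new or still open speak of the compounds shown alone.

Compound 3 `CC(C)[C@H](C)NC(=O)c1ccc(C#Cc2cccc(F)c2)cn1` was tested in a functional assay on HEK293 cells for positive allosteric modulation of metabotropic glutamate receptor 5 (Rattus norvegicus), read by fluorescence and calcium flux (on this read-out higher numbers stand for larger maximal responses and lower numbers for smaller maximal responses), where compound 3 gives 66.7%. Compound 1 `C[C@@H](NC(=O)c1ccc(C#CC2CC2)cn1)C(C)(C)O` gives 63.4% and compound 2 `C[C@@H](NC(=O)c1ccc(C#Cc2cccc(F)n2)cn1)C(C)(C)O` gives 63%, so compound 3 lies within the scatter of both. Among the measured compounds shown here, the only step measured here, a number 0.4 percentage points lower from compound 1 to compound 2 (within the scatter), changes the group on the triple-bonded carbon and not the amide nitrogen. Compound 4 `CC1(CNC(=O)c2ccc(C#Cc3cccc(F)c3)cn2)COC1` differs from compound 3 at that nitrogen: (3-methyloxetan-3-yl)methyl in place of 1,2-dimethylpropyl on an amide-type nitrogen. For the measured compounds named here, no measured step touches this position, so the expectation rests on the flat picture across compounds 1, 2 and 3. The step is expected to read a number 3.7 percentage points lower from compound 3 to compound 4 (within the scatter), nothing beyond the scatter. Compound 4 is therefore estimated at 63%, between 50% and 78%.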

Compound 4, largest response reached (reported as efficacy), in percent of the reference or control that the assay uses: 60.4%
Compound 4: the middle estimate sits 2.6 percentage points above what was measured; the range from low to high includes it.
By their numbers in this assay, from the lowest: compounds 4, 2, 1 and 3 (each within the scatter of the next).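

The amide nitrogen now has a measured step of its own in this assay (a number 6.3 percentage points lower from compound 3 to compound 4 (within the scatter)). This position therefore tolerates (3-methyloxetan-3-yl)methyl, with its four-membered ring and hydrogen-bond acceptor, in place of the open-chain 1,2-dimethylpropyl and its defined stereocentre, without the maximal response moving beyond the scatter. Nothing available explains this tolerance. On these data alone, it remains open whether a chain on this nitrogen ending in an amine or a carboxylic acid would fit equally well, and whether the oxetane swap reads the same with cyclopropyl or 6-fluoropyridin-2-yl on the triple-bonded carbon.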